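Halogen swaps on the benzyl group of the triazole series

This account rests on a few compounds, and the source may have more. Where it says the series, first, only, none or still open, it means among the compounds named here.

Compound 3 `Fc1ccc(Cn2cc(CCCOc3cccc4cccnc34)nn2)cc1F` gives 18.2 ug/mL in a functional assay on U-251 cells (Homo sapiens) for inhibition, read by sulforhodamine B assay, with a stated time of 48 h (on this read-out lower numbers stand for stronger inhibition of growth and higher numbers for weaker inhibition of growth), the higher of the two numbers on record; compound 2 `Brc1ccc(Cn2cc(CCCOc3cccc4cccnc34)nn2)cc1` gives 8.4 ug/mL, and the gap reads a 2.2-fold higher number from compound 2 to compound 3 (0.34 log units; beyond the scatter). Compound 1 `Ic1ccc(Cn2cc(CCCOc3cccc4cccnc34)nn2)cc1` yields only a limit, > 250 ug/mL, so it cannot be ranked beyond the statement (the limit of > 250 ug/mL in this assay, at which 1 of the 3 values shown sits). The halogen on the benzyl ring matters greatly here: an at least 29-fold lower number from compound 1 to compound 2 (1.47 log units; beyond the scatter) is the largest step in the set, while the change of pattern in a 2.2-fold higher number from compound 2 to compound 3 (0.34 log units; beyond the scatter) is modest.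

Compound 4 `Clc1ccc(Br)cc1Cn1cc(CCCOc2cccc3cccnc23)nn1` differs from compound 3 by 5-bromo-2-chlorophenyl in place of 3,4-difluorophenyl on a saturated chain carbon bound to an aromatic nitrogen. Going by the values given here, no measured step covers this exact exchange; the nearest evidence is that a bromo-bearing benzyl (compound 2) sits lower than the difluoro one (compound 3), whereas the iodo-bearing one (compound 1) gives only a limit. Compound 4 is therefore expected to move by a 1.5-fold lower number from compound 3 to compound 4 (0.18 log units; within the scatter), a modest step toward lower numbers, with wide uncertainty because the halogen effects seen in an at least 29-fold lower number from compound 1 to compound 2 (1.47 log units; beyond the scatter) are large. The estimate for compound 4 is 12 ug/mL, with a range from 4 ug/mL to 60 ug/mL.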

Compound 4, concentration for 50% growth inhibition: 8.7 ug/mL
Compound 4: middle estimate off by 1.4-fold (0.14 log units), on the high side; measured number inside the range.
By their numbers in this assay, from the lowest: compounds 2 and 4 (each within the scatter of the next); then compound 3. At a limit, above all of these: compound 1.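

The 5-bromo-2-chlorobenzyl group, on a saturated chain carbon bound to an aromatic nitrogen, brings two different halogens onto the ring and in this assay gives a 2.1-fold lower number from compound 3 to compound 4 (0.32 log units; beyond the scatter), a step beyond the scatter. Set against 4-bromophenyl, the same group gives a 1.0-fold higher number from compound 2 to compound 4 (0.02 log units; within the scatter), so the extra halogen produces no readable change, and the two bromo-bearing rings sit level with each other and below the 3,4-difluorophenyl ring. The remaining step, an at least 28-fold lower number from compound 1 to compound 4 (1.45 log units; beyond the scatter), rests on a limit and is only a bound: the limit of > 250 ug/mL in this assay, at which 1 of the 4 values shown sits.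

Going by these compounds, whether bromine itself sets the lower numbers stays open, since a 2-chlorobenzyl group alone would be needed to separate the two halogens. Also open, on these data alone, is how an unsubstituted benzyl, a trifluoromethyl-bearing benzyl or a ring amine would read at this position.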